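A few compounds are considered here, and "the series" means these few. Any claim that something is new, unique, unknown or untested is made for them only; others in the source may bear on it.

Going by the values given here, the series shares one core, and the three measured members carry different amide substituents. Compound 1 `NC(=O)Cn1c(-c2ccc(Br)cc2)nc2cccnc21` gives 17.8 mg/kg in a functional assay on the whole organism with Mus musculus as the target; a lower number here means that less compound is needed, a higher number that more compound is needed for the effect. Compound 2 `CN(C)C(=O)Cn1c(-c2ccc(Br)o2)nc2cccnc21` gives 100 mg/kg in this assay. Compound 3 `CCCNC(=O)Cn1c(-c2ccc(Cl)cc2)nc2cccnc21`, which carries a propyl group on the amide nitrogen, gives 37.5 mg/kg in this assay and stands second highest of the three numbers, its nearest neighbour being compound 1 and its furthest compound 2, with both gaps beyond the scatter.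

The next compound, compound 4 `O=C(Cn1c(-c2ccc(Cl)cc2)nc2cccnc21)Nc1cccnc1`, differs from compound 3 in one place: pyridin-3-yl in place of propyl on an amide-type nitrogen. Among the compounds with values here, no measured pair in the set makes this same exchange, so the size of its effect has no direct precedent here. The three measured values show that changes on the amide nitrogen move the dose by amounts beyond the scatter, without a single direction. Compound 4 is expected to need a dose of about 45 mg/kg, within a range from 15 mg/kg to 130 mg/kg. That estimate means a step of a 1.2-fold higher number from compound 3 to compound 4 (0.08 log units; within the scatter) that is expected to stay near the scatter, leaning slightly upward.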

Compound 4, dose for half-maximal effect: 100 mg/kg
Compound 4: middle estimate off by 2.2-fold (0.35 log units), on the low side; the measured number falls inside the stated range.
By their numbers in this assay, from the lowest: compound 1; then compound 3; then compounds 2 and 4 (each within the scatter of the next).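

In this assay, putting pyridin-3-yl in place of propyl on the amide-type nitrogen gives a 2.7-fold higher number from compound 3 to compound 4 (0.43 log units; beyond the scatter), so more compound is needed for the effect. Going by these compounds alone, with the rest of the molecule held constant, this pair isolates a single change at this position and shows that the exchange alone moves the dose beyond the scatter, which the earlier compounds, differing in more than one place, could not show. No available measurement accounts for this step.

Going by these compounds, what remains open is whether the rise follows the aromatic ring itself or the nitrogen within it, a question that a plain phenyl group on the same amide nitrogen could address. A butyl chain there would show how the dose responds to a longer chain without any ring.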